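This account rests on a few compounds, and the source may have more. Where it says the series, first, only, none or still open, it means among the compounds named here.

Compound 1 `COc1cccc(/C=N/c2c(C)n(C)n(-c3ccccc3)c2=O)c1`: 105000000 nM
Compound 2 `COc1ccc(/C=N/c2c(C)n(C)n(-c3ccccc3)c2=O)cc1OC`: 141000000 nM

For the measured compounds named here, in a functional assay on P388 cells (Mus musculus) for cytotoxicity, read by MTT assay, with a stated time of 72 h (a higher number here means a weaker inhibitor, a lower number a stronger inhibitor), compound 2 gives 141000000 nM, and its only measured neighbour is compound 1, whose number sits within the scatter of it. Compound 3 `COc1cc(/C=N/c2c(C)n(C)n(-c3ccccc3)c2=O)cc(OC)c1OC` has not yet been measured; it differs from compound 2 by methoxy in place of hydrogen on an aromatic carbon. Going by the values given here, the one measured step that bears on this change, a 1.3-fold higher number from compound 1 to compound 2 (0.13 log units; within the scatter), added a methoxy in place of hydrogen on an aromatic carbon in the same way and stayed within the scatter, so the step is expected to be a 1.1-fold higher number from compound 2 to compound 3 (0.03 log units; within the scatter), with no shift beyond the scatter in either direction. Compound 3 is therefore estimated at 150000000 nM, within a range of 60000000 nM to 400000000 nM.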

Compound 3, half-maximal inhibitory concentration: 501000000 nM
Estimate against measurement, compound 3: 3.3-fold (0.52 log units) below; measured number outside the range, above it.
By their numbers in this assay, from the lowest: compounds 1 and 2 (each within the scatter of the next); then compound 3.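

In this assay this third methoxy, ortho to a methoxy group and meta to another, gives a 3.6-fold higher number from compound 2 to compound 3 (0.55 log units; beyond the scatter) and so weakens the compound beyond the scatter. The same kind of swap had shown no such shift earlier, with a 1.3-fold higher number from compound 1 to compound 2 (0.13 log units; within the scatter) staying within the scatter, so the effect of adding a methoxy depends on where it goes or on what is already present. No measurement here gives a reason for this weakening.

On these data alone, whether a hydroxyl, an amine or a longer chain such as ethoxy at this position would weaken the compound to the same degree remains open.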